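The source may report more compounds than this note shows. Statements on the series, on what has been measured and on what is new or still open speak of the compounds shown alone.

Series notes. Compound 1 `Nc1nc(-c2ccc(Cl)o2)nc2sc(CN3CCC(F)CC3)cc12` gives 1080 nM in an assay on CHO-K1 cells for antagonist activity at adenosine receptor A1 (Homo sapiens), read by a beta-galactosidase reporter, with stated times of 15 min and 6 h; a lower number here means a stronger inhibitor, a higher number a weaker inhibitor; compound 2 `Nc1nc(-c2ccc(Cl)o2)nc2sc(CN3CC=CCC3)cc12` gives 190 nM; compound 3 `Nc1nc(-c2ccc(Cl)o2)nc2sc(CN3CC=CC3)cc12` gives 780 nM. Compound 3 therefore holds the second highest of the three numbers: the step of a 1.4-fold lower number from compound 1 to compound 3 (0.14 log units; within the scatter) stays within the scatter, whereas a 4.1-fold higher number from compound 2 to compound 3 (0.61 log units; beyond the scatter) lies beyond it, as does a 5.7-fold lower number from compound 1 to compound 2 (0.75 log units; beyond the scatter). Compound 4 `N#Cc1ccc(-c2nc(N)c3cc(CN4CC=CC4)sc3n2)cc1` differs from compound 3 by 4-cyanophenyl in place of 5-chlorofuran-2-yl on an aromatic carbon. Within the data shown here, every measured step alters the ring on the saturated chain carbon; none touches the position where 4-cyanophenyl enters, so no measured step bears on this change and neither size nor direction can be read from the numbers. A step of about no change at the digits printed from compound 3 to compound 4 (within the scatter) is expected, with a broad range. Compound 4 is estimated at 780 nM, between 150 nM and 4000 nM.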

Compound 4, inhibition constant: 2350 nM
Compound 4: middle estimate off by 3.0-fold (0.48 log units), on the low side, and the stated range covers the measured number.
By their numbers in this assay, from the lowest: compound 2; then compounds 3 and 1 (each within the scatter of the next); then compound 4.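

Among these compounds, the position between two ring nitrogen atoms, which no earlier step touched, does respond to change: in this assay, 4-cyanophenyl in place of 5-chlorofuran-2-yl gives (a 3.0-fold higher number from compound 3 to compound 4 (0.48 log units; beyond the scatter)). Among the compounds shown here, this is the only reading at this position, and it holds only with the five-membered ring of compound 3 on the saturated chain carbon. No evidence on hand accounts for the step.

Going by these compounds, whether the same change carries over to the six-membered ring of compound 2 remains open. Also open, on these data alone, is how plain phenyl or unsubstituted furan-2-yl would read here, which would separate the nitrile and the chlorine from their rings.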